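The source may hold more compounds than are shown below. What is called first, only, known or untested is meant among the compounds shown, and "the series" means these compounds.

Measured so far:
compound 1, `CC(C)[C@H](C(=O)Nc1ccc(F)cn1)c1ccc(Cl)cc1`, 1300 nM
compound 2, `CC(C)[C@H](C(=O)Nc1ccon1)c1ccc(Cl)cc1`, 36000 nM

Compound 2 stands as the highest of the two numbers in a functional assay on CHO cells for agonist activity at Free fatty acid receptor 2 (Homo sapiens), read by cAMP accumulation; a lower number here means a stronger inhibitor, a higher number a weaker inhibitor; its nearest neighbour is compound 1, and the step of a 28-fold higher number from compound 1 to compound 2 (1.44 log units; beyond the scatter) lies beyond the scatter. Compound 3, `Cc1csc(NC(=O)[C@H](c2ccc(Cl)cc2)C(C)C)n1`, differs from compound 2 in one place: 4-methyl-1,3-thiazol-2-yl in place of 1,2-oxazol-3-yl on an amide-type nitrogen. Among the measured compounds shown here, only one measured step bears on this change, the exchange of one amide-nitrogen heteroaryl for another in a 28-fold higher number from compound 1 to compound 2 (1.44 log units; beyond the scatter), which shows that this assay responds strongly to the group carried on the amide-type nitrogen. For the measured compounds named here, no measured pair contains the 4-methyl-1,3-thiazol-2-yl group, so its own effect is not known here. Given that compound 1 and compound 2 differ so widely and that compound 2 holds the weakest number shown, compound 3 is expected to move away from compound 2 toward compound 1, that is, toward a lower number, with a step estimated as a 14-fold lower number from compound 2 to compound 3 (1.16 log units; beyond the scatter). Compound 3 is therefore estimated at 2500 nM in this assay, with a likely range from 400 nM to 15000 nM.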

Compound 3, half-maximal inhibitory concentration: 1400 nM
The estimate for compound 3 lay 1.8-fold (0.25 log units) above the measured number; low and high end bracket the measured number.
By their numbers in this assay, from the lowest: compounds 1 and 3 (each within the scatter of the next); then compound 2.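

In this assay, the exchange on the amide-type nitrogen gives a 26-fold lower number from compound 2 to compound 3 (1.41 log units; beyond the scatter), although 1,2-oxazol-3-yl and 4-methyl-1,3-thiazol-2-yl are each one five-membered aromatic ring with 2 hetero atoms, with matching hydrogen-bond donor and acceptor counts and no net charge, so these counts alone do not decide the number at this position. The earlier step also cannot be read as a simple divide between five-membered and six-membered rings: a five-membered ring group now shows a 1.1-fold higher number from compound 1 to compound 3 (0.03 log units; within the scatter) against 5-fluoropyridin-2-yl, which leaves compound 2 as the only one of the three set apart, beyond the scatter from both others. Nothing measured on these compounds accounts for the gap between the two five-membered ring groups.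

The two groups differ in both the ring atoms and the methyl, so the compounds shown cannot separate the contribution of sulfur in the ring from that of the methyl; the plain 1,3-thiazol-2-yl group would bear on this. Also open, from the compounds shown here alone, is whether an ethyl group, an amine or a carboxylic acid in place of that methyl would keep the number of compound 3.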